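The compounds below may be only part of what the source reports. "The series", "measured", "known", "first", "only" and "open" are said of these compounds alone.

Measured so far in a functional assay on SW480 cells (Homo sapiens) for cytotoxicity, read by MTT assay, with a stated time of 24 h; a lower number here means a stronger inhibitor, a higher number a weaker inhibitor:
compound 1 `C=CC1=C(C(=O)Nc2ccccc2)C(c2ccc(OC)cc2)OC1` — in this assay compound 1 gives > 100000 nM, a limit of the assay.
compound 2 `C=CC1=C(C(=O)NCc2ccccc2F)C(c2ccc(OC)cc2)OC1` — in this assay compound 2 gives > 100000 nM, likewise a limit.

Compound 2 therefore stands only at a limit, and the limit of > 100000 nM in this assay, at which 2 of the 2 values shown sit, is all the numbers show. Within the data shown here, the one measured step on the amide nitrogen, a step that the two limits leave unreadable from compound 1 to compound 2, has limits at both ends and gives no size. Compound 3 `C=CC1=C(C(=O)Nc2ccccc2OC)C(c2ccc(OC)cc2)OC1` is unmeasured and differs from compound 2 by 2-methoxyphenyl in place of 2-fluorobenzyl on an amide-type nitrogen. With no readable step to lean on, no direction is expected in this assay. Compound 3 is expected at 150000 nM, within 50000 nM to 500000 nM. The expected step that the limit leaves unreadable from compound 2 to compound 3 is none beyond the scatter.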

Compound 3, half-maximal inhibitory concentration: > 100000 nM
Compound 3: a limit, no number; the forecaster's own chance of this, stated with the estimate: 85%; the middle value is on the limit's open side.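

In this assay no new step can be read among compound 1, compound 2 and compound 3, because all three stand at a limit, not a number: the limit of > 100000 nM in this assay, at which 3 of the 3 values shown sit.

The compounds shown leave open whether any group on the amide-type nitrogen gives a readable value in this assay at all.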